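Sulfur to oxygen in the ring of the strongest binder

A few compounds are considered here, and "the series" means these few. Any claim that something is new, unique, unknown or untested is made for them only; others in the source may bear on it.

Measured so far:
compound 1 `CC(C)[C@@H](c1ccc(-c2ccc3cccc(F)c3c2)[nH]c1=O)[C@@H]1OC(=O)NC1=O` — 85 nM
compound 2 `CC(C)[C@@H](c1ccc(-c2ccc3cccc(F)c3c2)[nH]c1=O)[C@H]1OC(=O)NC1=O` — 27 nM
compound 3 `CC(C)[C@H](C[C@H]1SC(=O)NC1=O)c1ccc(-c2ccc3cccc(F)c3c2)[nH]c1=O` — 8 nM

In an assay on membranes from Chem-1 cells for displacement of a labelled ligand from prostaglandin E2 receptor EP3 subtype (Homo sapiens), read by scintillation counting, with a stated time of 2 h (a higher number here means a weaker inhibitor, a lower number a stronger inhibitor), compound 3 gives the lowest number of the three, with compound 2 nearest and compound 1 furthest. The step of a 3.1-fold lower number from compound 1 to compound 2 (0.50 log units; beyond the scatter) rests on (the fact that compounds 1 and 2 differ only in the configuration as drawn). Compound 4 `CC(C)[C@H](C[C@@H]1OC(=O)NC1=O)c1ccc(-c2ccc3cccc(F)c3c2)[nH]c1=O` differs from compound 3 by 2,4-dioxo-1,3-oxazolidin-5-yl in place of 2,4-dioxo-1,3-thiazolidin-5-yl on a saturated chain carbon, two bonds along the chain from an aromatic carbon. Among the measured compounds shown here, two measured steps bear on this: an 11-fold lower number from compound 1 to compound 3 (1.03 log units; beyond the scatter) and a 3.4-fold lower number from compound 2 to compound 3 (0.53 log units; beyond the scatter), both of which combine the heteroatom exchange with a change in chain length, so no measured pair isolates the exchange alone. Since both favoured the sulfur ring, a modest weakening is expected for compound 4, a 2.5-fold higher number from compound 3 to compound 4 (0.40 log units; beyond the scatter). Compound 4 is therefore estimated at 20 nM in this assay, with a range of 7 nM to 60 nM.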

Compound 4, inhibition constant in the prostaglandin E2 receptor EP3 subtype assay: 8 nM
Beside the measured number, compound 4's estimate is 2.5-fold (0.40 log units) above it; the range from low to high includes it.
By their numbers in the prostaglandin E2 receptor EP3 subtype assay, from the lowest: compounds 3 and 4 (each within the scatter of the next); then compound 2; then compound 1.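

In the prostaglandin E2 receptor EP3 subtype assay compound 3 gives 8 nM and compound 4 gives 8 nM. In the prostaglandin E2 receptor EP3 subtype assay the exchange of 2,4-dioxo-1,3-thiazolidin-5-yl for 2,4-dioxo-1,3-oxazolidin-5-yl, on a saturated chain carbon, two bonds along the chain from an aromatic carbon, gives no change at the digits printed from compound 3 to compound 4 (within the scatter), so sulfur and oxygen in this ring cannot be told apart here. With the oxygen ring kept, the prostaglandin E2 receptor EP3 subtype assay shows that (2,4-dioxo-1,3-oxazolidin-5-yl)methyl gives a 3.4-fold lower number from compound 2 to compound 4 (0.53 log units; beyond the scatter) and an 11-fold lower number from compound 1 to compound 4 (1.03 log units; beyond the scatter), so the earlier gains for compound 3 track the methyl link, not sulfur. In a physicochemical assay for solubility, in phosphate buffer, measured as kinetic solubility (a higher number here means a more soluble compound, a lower number a less soluble compound), compound 3 gives 31200 nM and compound 4 gives 21100 nM. In the physicochemical assay the exchange gives a 1.5-fold lower number from compound 3 to compound 4 (0.17 log units; within the scatter), and the evidence available bears on neither result.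

Going by these compounds, whether a longer chain would carry the ring equally well remains open. So does whether a carboxylic acid could replace the ring.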